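Loss of the phenolic hydroxy in the arylidene series

A few compounds are considered here, and "the series" means these few. Any claim that something is new, unique, unknown or untested is made for them only; others in the source may bear on it.

In a functional assay on MCF7 cells (Homo sapiens) for cytotoxicity, read by MTT assay, with a stated time of 72 h (on this read-out higher numbers stand for weaker inhibition and lower numbers for stronger inhibition), compound 1 `O=C1C(=Cc2ccc(O)cc2)C(=O)N(c2ccc(Cl)cc2)N1c1ccc(Cl)cc1` gives 23200 nM, the highest of the two numbers seen. Compound 3 `COc1cc(C=C2C(=O)N(c3ccc(Cl)cc3)N(c3ccc(Cl)cc3)C2=O)ccc1O` gives 22800 nM, and the step of a 1.0-fold lower number from compound 1 to compound 3 (0.01 log units; within the scatter) is within the scatter: methoxy in place of hydrogen on an aromatic carbon, with the hydroxy kept, does nothing measurable. Compound 2 `CN(C)c1ccc(C=C2C(=O)N(c3ccc(Cl)cc3)N(c3ccc(Cl)cc3)C2=O)cc1` gives only a limit, > 128000 nM, and not a number. This is the limit of > 128000 nM in this assay, at which 1 of the 3 values shown sits. The step of an at least 5.5-fold higher number from compound 1 to compound 2 (0.74 log units; beyond the scatter) shows that dimethylamino in place of hydroxy on an aromatic carbon weakened inhibition beyond the scatter, and an at least 5.6-fold lower number from compound 2 to compound 3 (0.74 log units; beyond the scatter) runs back the other way.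

Compound 4 `COc1cccc(C=C2C(=O)N(c3ccc(Cl)cc3)N(c3ccc(Cl)cc3)C2=O)c1` differs from compound 1 as follows: 3-methoxyphenyl in place of 4-hydroxyphenyl on a double-bonded chain carbon bound to a double-bonded ring carbon. The change removes the hydroxy donor, as in the step to compound 2, and moves the methoxy seen in compound 3 to a ring position without the hydroxy. The step to compound 3 bears only on the methoxy, which was neutral; the step to compound 2 bears on losing the hydroxy, which cost potency. A weakening beyond the scatter is therefore expected for compound 4, though smaller than for compound 2 since a methoxy is not a dimethylamino. For compound 4 the expected step is a 2.4-fold higher number from compound 1 to compound 4 (0.37 log units; beyond the scatter). Compound 4 is estimated at 55000 nM, between 20000 nM and 150000 nM.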

Compound 4, half-maximal inhibitory concentration: 18100 nM
The estimate for compound 4 lay 3.0-fold (0.48 log units) above the measured number; the measured number lies below the stated range.
By their numbers in this assay, from the lowest: compounds 4, 3 and 1 (each within the scatter of the next). At a limit, above all of these: compound 2.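

In this assay, the hydroxy proves dispensable: 3-methoxyphenyl in place of 4-hydroxyphenyl on a double-bonded chain carbon bound to a double-bonded ring carbon gives a 1.3-fold lower number from compound 1 to compound 4 (0.11 log units; within the scatter), and hydrogen in place of hydroxy on an aromatic carbon gives a 1.3-fold lower number from compound 3 to compound 4 (0.10 log units; within the scatter). Compound 4 has no hydrogen-bond donor in this group, yet the series shows an at least 7.0-fold lower number from compound 2 to compound 4 (0.84 log units; beyond the scatter), so losing the hydroxy does not by itself account for compound 2 standing apart; among the compounds shown, that separation goes with the 4-(dimethylamino)phenyl group. Compound 2 remains a limit of the assay and not a number, so the true size of its separation stays unknown: the limit of > 128000 nM in this assay, at which 1 of the 4 values shown sits.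

Open, as far as these compounds go, is whether the loss belongs to the dimethylamino group specifically, which a primary amine or a carboxylic acid on the same aromatic ring would test. Also open, from the compounds shown here alone, is how far any substituent can be changed on this ring before the number moves beyond the scatter, as a longer alkoxy chain in place of the methoxy would show.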